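The compounds below may be only part of what the source reports. "The series", "measured", "known", "first", "only" and "open" are said of these compounds alone.

Compound 2 `Cc1nc2ccc(CN(CC(N)=O)c3ccc(C(=O)N[C@@H](CCC(=O)O)C(=O)O)c(F)c3)cc2c(=O)[nH]1` gives 1340 nM in an assay on isolated protein for inhibition of Thymidylate synthase (Mus musculus) (a higher number here means a weaker inhibitor, a lower number a stronger inhibitor), the highest of the two numbers recorded so far; its nearest neighbour is compound 1 `CCN(Cc1ccc2nc(C)[nH]c(=O)c2c1)c1ccc(C(=O)N[C@@H](CCC(=O)O)C(=O)O)c(F)c1`, which in this assay gives 45 nM. Compound 3 `Cc1nc2ccc(CN(C)c3ccc(C(=O)N[C@@H](CCC(=O)O)C(=O)O)c(F)c3)cc2c(=O)[nH]1` differs from compound 2 by hydrogen in place of carbamoyl on a saturated chain carbon bound to a nitrogen on an aromatic ring. Among the compounds with values here, the only measured step that bears on this change is a 30-fold higher number from compound 1 to compound 2 (1.47 log units; beyond the scatter), which introduced the carbamoyl; compound 3 removes it again, so a large step toward a lower number is expected. Compound 3 is therefore estimated at 80 nM, between 25 nM and 250 nM, which would mean a step of a 17-fold lower number from compound 2 to compound 3 (1.22 log units; beyond the scatter).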

Compound 3, half-maximal inhibitory concentration: 120 nM
Compound 3: the middle estimate sits 1.5-fold (0.18 log units) below what was measured, and the stated range covers the measured number.
By their numbers in this assay, from the lowest: compound 1; then compound 3; then compound 2.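

Taking the carbamoyl off this chain carbon in this assay gives an 11-fold lower number from compound 2 to compound 3 (1.05 log units; beyond the scatter) and so undoes most of the loss tied to that group. The position also responds to a much smaller change: hydrogen in place of methyl gives a 2.7-fold higher number from compound 1 to compound 3 (0.43 log units; beyond the scatter), a modest step, and the methyl-bearing compound 1 keeps the lowest number of the three. No evidence on hand accounts for these shifts. From the compounds shown here alone, whether a longer chain, an amine or a carboxylic acid on this carbon would lower the number further remains open.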